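The compounds below may be only part of what the source reports. "The series", "measured", "known", "first", "only" and "open" are said of these compounds alone.

Within the data shown here, in a functional assay on DU-145 cells (Homo sapiens) for inhibition, read by trypan blue exclusion, with a stated time of 96 h (a higher number here means a weaker inhibitor of growth, a lower number a stronger inhibitor of growth), compound 1 `Cc1ccc(S(=O)(=O)/C(=C/c2ccc(O)c([N+](=O)[O-])c2)C(=O)c2ccc(Cl)cc2)cc1` gives 25000 nM, the highest of the three numbers measured so far. Compound 2 `O=C(/C(=C\c1ccc(O)c([N+](=O)[O-])c1)SCc1ccccc1Cl)c1ccc(Cl)cc1` gives 10000 nM, and compound 3 `O=C(/C(=C\c1ccc(O)c([N+](=O)[O-])c1)S(=O)(=O)Cc1ccccc1Cl)c1ccc(Cl)cc1` gives 10000 nM. Both differ from compound 1 only on the sulfur side, with steps of a 2.5-fold lower number from compound 1 to compound 2 (0.40 log units; beyond the scatter) and a 2.5-fold lower number from compound 1 to compound 3 (0.40 log units; beyond the scatter). Both are modest steps toward stronger growth inhibition.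

Compound 4 `COc1ccc(/C=C(\C(=O)c2ccc(Cl)cc2)S(=O)(=O)c2ccc(C)cc2)cc1O` keeps that sulfur side of compound 1 and changes the other end: 3-hydroxy-4-methoxyphenyl in place of 4-hydroxy-3-nitrophenyl on a double-bonded chain carbon bound to a double-bonded chain carbon. Here, 3-hydroxy-4-methoxyphenyl stands in place of 4-hydroxy-3-nitrophenyl. Neither measured step alters this group, so they offer only a rough sense of scale, and the real step could be larger. A lower number seems somewhat likelier than a higher one, since compound 1 gives 25000 nM, the top of the measured numbers, but this is weak evidence. The expected change is a 4.2-fold lower number from compound 1 to compound 4 (0.62 log units; beyond the scatter). For compound 4 the estimated value is 6000 nM, with an expected range from 700 nM to 30000 nM.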

Compound 4, concentration for 50% growth inhibition: 1000 nM
Compound 4: middle estimate off by 6.0-fold (0.78 log units), on the high side; low and high end bracket the measured number.
By their numbers in this assay, from the lowest: compound 4; then compounds 2 and 3 (each within the scatter of the next); then compound 1.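

In this assay, this position on a double-bonded chain carbon bound to a double-bonded chain carbon proves far more sensitive than the sulfur side: placing 3-hydroxy-4-methoxyphenyl there instead of 4-hydroxy-3-nitrophenyl gives a 25-fold lower number from compound 1 to compound 4 (1.40 log units; beyond the scatter), a much larger step than a 2.5-fold lower number from compound 1 to compound 2 (0.40 log units; beyond the scatter) or a 2.5-fold lower number from compound 1 to compound 3 (0.40 log units; beyond the scatter). The swap is not a single small edit, since the nitro group leaves, a methoxy group enters and the hydroxy group sits at a different ring position, so this one step cannot show which of these changes carries the gain. Nothing measured here explains why the number falls so far.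

From the compounds shown here alone, it remains open whether a phenyl ring with only a hydroxy group, or with an amine in place of the methoxy group, would hold this gain. Going by these compounds, it is also open whether the same ring change would give a step of similar size with the 2-chlorobenzyl group on the sulfonyl sulfur of compound 3.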